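The source may hold more compounds than are shown below. What is called first, only, known or untested is meant among the compounds shown, and "the series" means these compounds.

Measured so far in a functional assay on the whole organism (B cells) with Mus musculus as the target; a higher number here means a larger maximal response, a lower number a smaller maximal response:
- compound 1, `Nc1nc(O)c2c(n1)n(C1OC(CO)[C@@H](O)[C@H]1O)c(=O)n2CC(O)CSc1ccccc1`, with compound 1 giving 12%
- compound 2, `Nc1nc(O)c2c(n1)n(C1OC(CO)[C@@H](O)[C@H]1O)c(=O)n2Cc1ccc([N+](=O)[O-])cc1`, with compound 2 giving 147%

Compound 2 holds the highest of the two numbers; the nearest, compound 1, stands well below it, the step of a number 135 percentage points higher from compound 1 to compound 2 (beyond the scatter) lying beyond the scatter. That step swaps 4-nitrophenyl for 1-hydroxy-2-(phenylsulfanyl)ethyl on a saturated chain carbon bound to an aromatic nitrogen, a change at the same place as the one now considered but of a different kind.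

Compound 3, `Nc1nc(O)c2c(n1)n(C1OC(CO)[C@@H](O)[C@H]1O)c(=O)n2Cc1ccccc1`, differs from compound 2 as follows: hydrogen in place of nitro on an aromatic carbon. Among the measured compounds shown here, the one measured step concerns a different group and gives no direct read on removing nitro from a 4-nitrophenyl; it shows only that this position moves the maximal response strongly. With compound 2 at the top of the series and nothing measured for a plain benzyl, the expected step of a number 47 percentage points lower from compound 2 to compound 3 (beyond the scatter) is a moderate fall, with wide uncertainty. Compound 3 is therefore estimated at 100%, within 40% to 160%.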

Compound 3, largest response reached (reported as maximal response), in percent of the reference or control that the assay uses: 110%
For compound 3 the middle estimate is 10 percentage points below the measured one; the measured number falls inside the stated range.
By their numbers in this assay, from the lowest: compound 1; then compound 3; then compound 2.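

In this assay, the nitro group turns out to matter in its own right: a number 37 percentage points lower from compound 2 to compound 3 (beyond the scatter), so the substituent on the aromatic carbon para to a large group moves the maximal response, and the earlier step could not separate this from the effect of the benzyl unit as a whole. The plain benzyl still stands clearly apart from the side chain of compound 1, with a number 98 percentage points higher from compound 1 to compound 3 (beyond the scatter), so the high response in this small set does not depend on the nitro group, although compound 2 with nitro stays on top. No accompanying measurement bears on why either step occurs, and the numbers give only their size and direction.

Still open, from the compounds shown here alone, is whether the drop on going from 4-nitrobenzyl to benzyl is particular to nitro or would also follow from another group on that aromatic carbon, such as an amine, a carboxylic acid or a methoxy group. Also open, going by these compounds, is how a longer chain between the phenyl ring and the aromatic nitrogen would fare, and which part of the side chain of compound 1, its hydroxyl or its phenylsulfanyl, goes with the low response.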